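A few compounds are considered here, and "the series" means these few. Any claim that something is new, unique, unknown or untested is made for them only; others in the source may bear on it.

Measured in a functional assay on HOP-62 cells (Homo sapiens) for inhibition, read by sulforhodamine B assay; a higher number here means a weaker inhibitor of growth, a lower number a stronger inhibitor of growth:
- Compound 1 `Cc1ccc2[nH]c(-c3ccc(-c4ccc(-c5ccc(N(C)C)cc5)cc4)cc3)nc2c1`: 4230 nM
- Compound 2 `COc1ccc(-c2ccc(-c3ccc(-c4nc5cc(C)ccc5[nH]4)cc3)cc2)cc1OC`: 2120 nM

Among the measured compounds shown here, only two compounds have numbers so far, and they cannot be ranked. The measured step between them is a 2.0-fold lower number from compound 1 to compound 2 (0.30 log units; within the scatter). Compound 2, at 2120 nM, therefore stands level with compound 1 for practical purposes.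

Compound 3 `COc1cc(-c2ccc(-c3ccc(-c4nc5cc(C)ccc5[nH]4)cc3)cc2)cc(OC)c1OC` keeps all of compound 2 and changes one thing: methoxy in place of hydrogen on an aromatic carbon. In words, it has methoxy in place of hydrogen on an aromatic carbon. This carbon belongs to the same group that changed between compound 1 and compound 2. For the measured compounds named here, that single step is the only measured guide, and it stayed within the scatter even though a whole substituted phenyl group was exchanged. Going by the values given here, one step is thin evidence, and no compound yet shows what an added methoxy does here. A shift beyond the scatter is therefore not expected in this assay, and no direction is favoured. The expected change is a 1.1-fold lower number from compound 2 to compound 3 (0.03 log units; within the scatter). For compound 3 the estimated value is 2000 nM, with an expected range of 750 nM to 5500 nM.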

Compound 3, concentration for 50% growth inhibition: 2370 nM
Compound 3: middle estimate off by 1.2-fold (0.07 log units), on the low side, and the stated range covers the measured number.
By their numbers in this assay, from the lowest: compounds 2, 3 and 1 (each within the scatter of the next).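

In this assay, among the compounds shown here, the added methoxy, on the aromatic carbon ortho to one methoxy group and meta to another, gives a 1.1-fold higher number from compound 2 to compound 3 (0.05 log units; within the scatter) and so offers the first direct reading of a methoxy added to this group. The earlier exchange of the whole substituted phenyl group gave a 2.0-fold lower number from compound 1 to compound 2 (0.30 log units; within the scatter) and also stayed within the scatter, so neither of the two changes in this part of the molecule separates the compounds in this growth read-out. Nothing at hand explains this result.

The compounds shown leave open whether any substituent on this ring can shift the number beyond the scatter, and a hydroxyl, a fluorine or an amine in place of the new methoxy would be natural groups to compare. They also leave open whether a change elsewhere, such as a carboxylic acid in place of the methyl on the shared core, would matter more than these changes to the outer ring.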